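From furan-2-yl to thiophen-2-yl in compound 4

The source may hold more compounds than are shown below. What is called first, only, known or untested is meant among the compounds shown, and "the series" means these compounds.

Measured so far in a functional assay on A-431 cells (Homo sapiens) for inhibition, read by sulforhodamine B assay, with a stated time of 2 days (a lower number here means a stronger inhibitor of growth, a higher number a weaker inhibitor of growth), are three compounds:
- compound 1 `Cc1ccc(NC(=O)c2c(C)nc(S(=O)(=O)Cc3ccccc3)nc2-c2ccc(O)cc2O)cc1` gives 32000 nM
- compound 2 `CC1=C(C(=O)Nc2cccc([N+](=O)[O-])c2)C(c2ccc(O)cc2O)NC(N/N=C/c2cccs2)=N1` gives 19100 nM
- compound 3 `CC1=NN(C2=NC(C)=C(C(=O)Nc3cccc([N+](=O)[O-])c3)C(c3ccc(O)cc3O)N2)C(=O)/C1=C/c1ccco1` gives 15800 nM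

Compound 3 and compound 2 lie within the usual scatter of each other, so these two values cannot be ranked. Compound 1 stands beyond that scatter from compound 3, with a higher number and so weaker growth inhibition.

Compound 4 `CC1=NN(C2=NC(C)=C(C(=O)Nc3cccc([N+](=O)[O-])c3)C(c3ccc(O)cc3O)N2)C(=O)/C1=C/c1cccs1` has not been measured yet. It is compound 3 with thiophen-2-yl in place of furan-2-yl on a double-bonded chain carbon bound to a double-bonded ring carbon and nothing else changed. Among the measured compounds shown here, no measured pair shows what this swap does. Compound 2 also carries thiophen-2-yl and gives 19100 nM within the scatter of compound 3, but those two differ elsewhere too, so this is only a loose guide.

In this assay no change beyond the scatter is expected, and the estimated 1.1-fold lower number from compound 3 to compound 4 (0.02 log units; within the scatter) stays small. For compound 4 the estimate is 15000 nM with a range from 8000 nM to 28000 nM expected in repeat measurements.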

Compound 4, concentration for 50% growth inhibition: 37100 nM
Compound 4: middle estimate off by 2.5-fold (0.39 log units), on the low side, outside the stated range (above it).
By their numbers in this assay, from the lowest: compounds 3, 2, 1 and 4 (each within the scatter of the next, the first and the last beyond it).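

In this assay, among the compounds shown here, placing thiophen-2-yl in place of furan-2-yl gives a 2.3-fold higher number from compound 3 to compound 4 (0.37 log units; beyond the scatter), a modest weakening of growth inhibition and the first direct reading of any change at this position. The two groups match in heavy-atom count, ring size, hydrogen-bond counts and charge, with sulfur standing where oxygen stood, so even this close exchange on a double-bonded chain carbon bound to a double-bonded ring carbon shifts the result beyond the scatter. Nothing available here offers a reason for the step.

This single pair leaves open whether the same exchange would have a similar effect on a different core. It also leaves open how a pyridine ring or a dimethylamino group would fare at this position.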